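Chloro to Fluoro on the Shared Core

This account rests on a few compounds, and the source may have more. Where it says the series, first, only, none or still open, it means among the compounds named here.

This small set concerns an in vitro functional assay on HEK285-7 cells for antagonist activity at prostaglandin D2 receptor 2 (Homo sapiens), read by BRET and beta-arrestin recruitment; a lower number here means a smaller maximal response, a higher number a larger maximal response. Compound 1 has the structure `COc1ccccc1Nc1nc(-c2ccc(F)cc2)c(CC(=O)O)s1` and compound 2 the structure `COc1ccccc1Nc1nc(-c2ccc(Cl)cc2)c(CC(=O)O)s1`; the two share a core and differ only in one group on the outer ring. In this assay compound 1 gives > 70%, which is a limit of the assay rather than a number. In this assay compound 2 likewise gives > 70%, again a limit. The change from compound 2 to compound 1 is fluoro in place of chloro on an aromatic carbon, and a step that the two limits leave unreadable from compound 2 to compound 1. That this step cannot be sized follows from the limit of > 70% in this assay, at which 3 of the 3 values shown sit.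

Compound 3, with the structure `O=C(O)Cc1sc(Cc2ccccc2)nc1-c1ccc(Cl)cc1`, carries a different core; how its core differs from that of compound 2 is not broken down here. In this assay compound 3 gives > 70%, a limit once more.

Compound 4 has the structure `O=C(O)Cc1sc(Cc2ccccc2)nc1-c1ccc(F)cc1` and has not yet been measured. For the measured compounds named here, it differs from compound 3 by fluoro in place of chloro on an aromatic carbon, the same change at the same kind of place as the one separating compound 2 from compound 1. The step is expected to be a step that the limit leaves unreadable from compound 3 to compound 4, because compound 3 already sits at > 70% and because the measured pair gave a step that the two limits leave unreadable from compound 2 to compound 1. Compound 4 is therefore estimated to give 85% in this assay, with the expected range running from 70% to 100%.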

Compound 4, largest response reached (reported as efficacy), in percent of the reference or control that the assay uses: 30%
Beside the measured number, compound 4's estimate is 55 percentage points above it, outside the stated range (below it).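

On the core of compound 3, going from 4-chlorophenyl to 4-fluorophenyl in this assay gives a number at least 40 percentage points lower from compound 3 to compound 4 (beyond the scatter), so on this core a swap of one halogen for another moves the maximal response by far more than the usual scatter. The same change on the core shared by compound 1 and compound 2 cannot be read, because both compounds sit at a limit, so the two cores cannot be compared and nothing shows whether the change acts alike or differently on them: the limit of > 70% in this assay, at which 3 of the 4 values shown sit. The result therefore shows that this change can matter in this series, but one readable pair cannot show that its effect carries over from one core to another, nor why the response drops.

The compounds shown leave open how other groups at the same place on the core of compound 3, such as bromo, methyl or an amine, would read in this assay. They also leave open whether numbers in place of the limits for compound 1 and compound 2 would reveal a step of similar size on that core.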